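This account rests on a few compounds, and the source may have more. Where it says the series, first, only, none or still open, it means among the compounds named here.

In an ADME assay on a cell-free system (plasma, Homo sapiens) for protein binding, three compounds sharing one core have been measured so far. Compound 1 `CNc1nccc(N2CC[C@H](NC(=O)Nc3ccc(CN(C)C)c(C(F)(F)F)c3)C2)n1` stands at 94.3% and compound 2 `CNc1nccc(N2CC[C@H](NC(=O)Nc3cccc(C#N)c3)C2)n1` at 94.4%. Compound 3 `CNc1nccc(N2CC[C@H](NC(=O)Nc3ccc(Cl)c(C(F)(F)F)c3)C2)n1` reads 99.8% and so has the lowest unbound fraction of the three, well beyond the scatter from either of the others.

Compound 4 `CNc1nccc(N2CC[C@H](NC(=O)Nc3ccc(CN4CCC4)c(C(F)(F)F)c3)C2)n1` has not been measured yet. It carries (azetidin-1-yl)methyl in place of chloro on an aromatic carbon, ortho to a trifluoromethyl group, and the change from compound 3 counts as follows: (azetidin-1-yl)methyl in place of chloro on an aromatic carbon.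

Going by the values given here, one measured step bears on this. Putting chloro in place of (dimethylamino)methyl on that same carbon gave a 29-fold lower unbound fraction from compound 1 to compound 3 (1.45 log units; beyond the scatter), a large step. Compound 4 makes the same kind of swap in the opposite direction, with (azetidin-1-yl)methyl as the incoming group, so a large rise in the unbound fraction is expected. Among the compounds with values here, compound 2 offers no matching step, and no compound with (azetidin-1-yl)methyl has been measured, so this expectation rests on a single precedent and its range stays wide.

The expected step is a 30-fold higher unbound fraction from compound 3 to compound 4 (1.48 log units; beyond the scatter). Compound 4 is expected at 94%, with an estimated range from 88% to 97.5%.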

Compound 4, plasma protein binding: 86.3%
The estimate for compound 4 lay 2.3-fold (0.36 log units) (unbound fraction) below the measured number; measured number outside the range, below it.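

In this assay, replacing chloro at this aromatic carbon, ortho to a trifluoromethyl group, with (azetidin-1-yl)methyl gives a 69-fold higher unbound fraction from compound 3 to compound 4 (1.84 log units; beyond the scatter). Compound 1 had shown a large difference of this kind with (dimethylamino)methyl alone, and compound 4 now shows that it is not tied to that one group: two different amine-bearing methyl groups at this carbon both leave far more of the compound free than chloro does. The two groups are not interchangeable, however, as azetidin-1-yl in place of dimethylamino on the saturated chain carbon gives a 2.4-fold higher unbound fraction from compound 1 to compound 4 (0.38 log units; beyond the scatter), a modest step but one beyond the scatter, and nothing at hand explains either step.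

The compounds shown leave open how the unbound fraction responds to larger rings on the same methyl group, such as pyrrolidin-1-yl, piperidin-1-yl or morpholin-4-yl. They also leave open what a longer chain between the aromatic ring and the amine, or a carboxylic acid at this carbon, would do in this assay.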